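The compounds below may be only part of what the source reports. "The series", "measured", "known", "first", "only" and "open" are said of these compounds alone.

Measured so far:
compound 1, `N#Cc1c(N)nc(SCC(N)=O)c(C#N)c1-c1ccc(OCC2CC2)cc1`: 31 nM
compound 2, `N#Cc1c(N)nc(SCC(=O)NCO)c(C#N)c1-c1ccc(OCC2CC2)cc1`: 182 nM

Both numbers come from a functional assay on CHO cells for agonist activity at adenosine receptor A2b (Homo sapiens), read by AlphaScreen and cAMP accumulation; on this read-out lower numbers stand for an effect already at smaller amounts and higher numbers for an effect only at larger amounts of compound. Among the compounds with values here, compound 2 stands at the higher of the two numbers; its nearest neighbour is compound 1, and the one measured step runs a 5.9-fold higher number from compound 1 to compound 2 (0.77 log units; beyond the scatter), so compound 2 needs more material for the same effect than compound 1 does.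

Compound 3, `N#Cc1c(N)nc(SCc2cccc(C(N)=O)c2)c(C#N)c1-c1ccc(OCC2CC2)cc1`, has not been measured. Its change from compound 2 is 3-carbamoylphenyl in place of (hydroxymethyl)carbamoyl on a saturated chain carbon bound to a sulfur. Within the data shown here, the only measured step bears on this in part: it shows what the hydroxymethyl on the amide-type nitrogen did, and in compound 3 that group is gone, so a return toward the number of compound 1 is plausible. Among the measured compounds shown here, the entering aromatic ring with its carboxamide has no counterpart among the measured compounds, so its effect is unknown and the estimate carries a wide range.

Compound 3 is therefore expected to give about 60 nM in this assay, with a range from 15 nM to 300 nM. The expected step is a 3.0-fold lower number from compound 2 to compound 3 (0.48 log units; beyond the scatter).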

Compound 3, half-maximal effective concentration: 12.7 nM
Beside the measured number, compound 3's estimate is 4.7-fold (0.67 log units) above it, and the stated range ends above it.
By their numbers in this assay, from the lowest: compound 3; then compound 1; then compound 2.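

In this assay, replacing the (hydroxymethyl)carbamoyl group with 3-carbamoylphenyl on the saturated chain carbon bound to a sulfur gives a 14-fold lower number from compound 2 to compound 3 (1.16 log units; beyond the scatter), a large step. This is more than simply undoing the hydroxymethyl change, since replacing the plain carbamoyl group with 3-carbamoylphenyl still gives a 2.4-fold lower number from compound 1 to compound 3 (0.39 log units; beyond the scatter), so this position accepts a much larger group, with a six-membered aromatic ring, and the number still falls. Nothing available explains why the ring-bearing group gives the lowest number of the three.

The compounds shown leave open whether the gain comes from the aromatic ring itself or from the carboxamide it carries, a question that a plain benzyl group, or a benzyl group bearing a carboxylic acid or an amine in place of the carboxamide, would help to settle. They also leave open whether the same change holds at the other adenosine receptors, since all three numbers come from this one receptor.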